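Swapping the aryl group on a hydrazone urea series

The compounds below may be only part of what the source reports. "The series", "measured", "known", "first", "only" and "open" are said of these compounds alone.

Measured so far:
- compound 1, `COc1cc2c(Oc3ccc(NC(=O)N/N=C/c4ccc(Cl)cc4Cl)cc3F)ccnc2cc1OCCCN1CCCCC1`: 460 nM
- compound 2, `COc1ccc(/C=N/NC(=O)Nc2ccc(Oc3ccnc4cc(OCCCN5CCC(C)CC5)c(OC)cc34)c(F)c2)cc1`: 470 nM
- compound 3, `COc1cc2c(Oc3ccc(NC(=O)N/N=C/c4ccc([N+](=O)[O-])cc4)cc3F)ccnc2cc1OCCCN1CCC(C)CC1`: 420 nM

All three compounds share one core and differ at the aryl group attached to the hydrazone and in the piperidine at the end of the side chain. In a functional assay on MKN-45 cells (Homo sapiens) for cytotoxicity, read by MTT assay, with a stated time of 72 h (on this read-out higher numbers stand for weaker inhibition and lower numbers for stronger inhibition), compound 3 gives 420 nM, the lowest of the three numbers, but its gaps to compound 1 and to compound 2 are both within the scatter, so no ordering can be read from them.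

Compound 4, `COc1cc2c(Oc3ccc(NC(=O)N/N=C/c4ccc(Cl)cc4Cl)cc3F)ccnc2cc1OCCCN1CCC(C)CC1`, carries 2,4-dichlorophenyl in place of 4-nitrophenyl on a carbon with a double bond to nitrogen. For the measured compounds named here, the one step that touches this position, a 1.1-fold lower number from compound 2 to compound 3 (0.05 log units; within the scatter), shows that exchanging one aryl group for another left the number essentially unchanged. Compound 1 already carries the 2,4-dichlorophenyl group and gives 460 nM in this assay, a value close to that of compound 3. The step of a 1.0-fold higher number from compound 3 to compound 4 (0.02 log units; within the scatter) is therefore expected to stay within the scatter. Compound 4 is estimated at 440 nM, with a range of 250 nM to 780 nM.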

Compound 4, half-maximal inhibitory concentration: 350 nM
Beside the measured number, compound 4's estimate is 1.3-fold (0.10 log units) above it; the measured number falls inside the stated range.
By their numbers in this assay, from the lowest: compounds 4, 3, 1 and 2 (each within the scatter of the next).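

In this assay, 2,4-dichlorophenyl on the carbon with a double bond to nitrogen cannot be told apart from either of the other aryl groups: replacing 4-nitrophenyl gives a 1.2-fold lower number from compound 3 to compound 4 (0.08 log units; within the scatter) and replacing 4-methoxyphenyl gives a 1.3-fold lower number from compound 2 to compound 4 (0.13 log units; within the scatter) at this position. The new compound also gives a direct reading of the end of the side chain, where methyl in place of hydrogen on a saturated ring carbon gives a 1.3-fold lower number from compound 1 to compound 4 (0.12 log units; within the scatter) with the 2,4-dichlorophenyl group held constant. No measured evidence bears on why these numbers stay so close.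

Going by these compounds, it remains open whether a pyridine ring, a phenyl ring carrying an amine or a carboxylic acid, or a longer alkyl chain in place of the aryl group would move the number beyond the scatter. A morpholine at the end of the side chain is equally untested among the compounds shown.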